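A few compounds are considered here, and "the series" means these few. Any claim that something is new, unique, unknown or untested is made for them only; others in the source may bear on it.

Among the measured compounds shown here, compound 2, `O=C(/C=C/c1cccs1)Nc1ccc2ncnc(Nc3cccc(Cl)c3)c2c1`, carries a thiophen-2-yl group on a double-bonded chain carbon bound to a double-bonded chain carbon; in a functional assay on B16-F10 cells (Mus musculus) for inhibition, read by MTT assay, with a stated time of 48 h (on this read-out lower numbers stand for stronger inhibition and higher numbers for weaker inhibition), compound 2 gives 4.26 ug/mL, the highest of the two numbers measured so far. Compound 1, `COc1cccc(/C=C/C(=O)Nc2ccc3ncnc(Nc4cccc(Cl)c4)c3c2)c1`, differs only at that position and in this assay compound 1 gives 1.05 ug/mL. For the measured compounds named here, the single step that joins them, a 4.1-fold higher number from compound 1 to compound 2 (0.61 log units; beyond the scatter), shows that the group on that chain carbon moves the read-out beyond the scatter. Compound 3, `O=C(/C=C/c1cccc2ccccc12)Nc1ccc2ncnc(Nc3cccc(Cl)c3)c2c1`, makes the next change: naphthalen-1-yl in place of thiophen-2-yl on a double-bonded chain carbon bound to a double-bonded chain carbon. Going by the values given here, since the only related step went to a higher number when a six-membered carbon ring gave way to thiophen-2-yl, returning to a larger all-carbon aromatic is expected to bring the number back down, giving an estimated step of a 2.8-fold lower number from compound 2 to compound 3 (0.45 log units; beyond the scatter). Compound 3 is therefore estimated at 1.5 ug/mL, within a range from 0.5 ug/mL to 5 ug/mL.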

Compound 3, half-maximal inhibitory concentration: 0.671 ug/mL
Beside the measured number, compound 3's estimate is 2.2-fold (0.35 log units) above it; low and high end bracket the measured number.
By their numbers in this assay, from the lowest: compounds 3 and 1 (each within the scatter of the next); then compound 2.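

In this assay, the change shows that thiophen-2-yl is the outlier at this chain carbon, with a 6.3-fold lower number from compound 2 to compound 3 (0.80 log units; beyond the scatter) for the move to naphthalen-1-yl. A larger group of two six-membered aromatic rings of carbon only is thus compatible with a low number here. The swap of naphthalen-1-yl for 3-methoxyphenyl gives a 1.6-fold lower number from compound 1 to compound 3 (0.19 log units; within the scatter) and so does not separate these two groups, which leaves compound 2 alone at the high end among the three compounds.

The compounds shown leave open how a plain phenyl, a pyridine ring, or a ring bearing an amine or a carboxylic acid would read at this chain carbon. They also leave open whether a second five-membered ring, such as furan-2-yl, would read like thiophen-2-yl. No available evidence explains why the number moves with the group at this position.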